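The source may report more compounds than this note shows. Statements on the series, on what has been measured and on what is new or still open speak of the compounds shown alone.

Within the data shown here, in a toxicity assay on microsomes from liver (Homo sapiens) for metabolic stability, read by LC-MS, using NADPH, tested at 1 uM (a higher number here means faster removal of the compound, a lower number slower removal), compound 2 `Cc1nc(C)n(CC(=O)N2CCN(c3sc(C(F)(F)F)nc3-c3cnc(C(C)(C)C)nc3)C[C@H]2C)n1` gives 449 mL.min-1.g-1, the higher of the two numbers so far, while compound 1 `Cc1nc(C)n(CC(=O)N2CCN(c3sc(C(F)(F)F)nc3-c3cnc(OC(C)C)nc3)C[C@H]2C)n1` gives 16 mL.min-1.g-1. Compound 3 `COc1ccc(-c2nc(C(F)(F)F)sc2N2CCN(C(=O)Cn3nc(C)nc3C)[C@H](C)C2)cn1` comes from compound 2 by this change: 6-methoxypyridin-3-yl in place of 2-(tert-butyl)pyrimidin-5-yl on an aromatic carbon. Among the measured compounds shown here, only one measured step bears on it, a 28-fold higher number from compound 1 to compound 2 (1.45 log units; beyond the scatter), which is large, beyond the scatter, and puts tert-butyl in place of isopropoxy. For the measured compounds named here, with the tert-butyl group leaving, a large step down is expected in this assay, although no measured compound carries 6-methoxypyridin-3-yl. The expected step is an 11-fold lower number from compound 2 to compound 3 (1.05 log units; beyond the scatter). For compound 3, the estimated value is 40 mL.min-1.g-1, within a range of 12 mL.min-1.g-1 to 150 mL.min-1.g-1.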

Compound 3, intrinsic clearance in microsomes: < 10 mL.min-1.g-1
Compound 3: only a limit was reported; the forecaster's own chance of this, stated with the estimate: 5%; at least 4.0-fold (0.60 log units) between middle value and limit.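

In this assay, 6-methoxypyridin-3-yl at this aromatic carbon gives an at least 44-fold lower number from compound 2 to compound 3 (1.65 log units; beyond the scatter), so a second group, besides isopropoxy on the pyrimidine, sits far under the tert-butyl compound. The other step reads an at least 1.6-fold lower number from compound 1 to compound 3 (0.20 log units; that floor lies within the scatter); with that floor inside the scatter, 6-methoxypyridin-3-yl and 2-isopropoxypyrimidin-5-yl cannot be ranked. The number for compound 3 is a limit and not a measured value: the limit of < 10 mL.min-1.g-1 in this assay, at which 1 of the 3 values shown sits.

From the compounds shown here alone, compound 3 changes the ring and loses tert-butyl together, and the share of each stays open. Going by these compounds, how an amine or a longer alkoxy chain on the pyrimidine would read in this assay also stays open.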